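An Ethoxy Group Enters the Shared Core

This account rests on a few compounds, and the source may have more. Where it says the series, first, only, none or still open, it means among the compounds named here.

Measured so far:
compound 1 `O=C1C(Nc2ccccc2)=CC(=O)c2c1nc1n2[C@H]2OC[C@@H](O)[C@H]2OC1`: > 4000 nM
compound 2 `COc1ccccc1NC1=CC(=O)c2nc3n(c2C1=O)[C@H]1OC[C@@H](O)[C@H]1OC3`: > 4000 nM

In a functional assay on MCF7 cells (Homo sapiens) for inhibition, read by sulforhodamine B assay (on this read-out lower numbers stand for stronger inhibition and higher numbers for weaker inhibition), compound 1 gives only a limit of the assay, > 4000 nM, not a number. Compound 2 likewise gives only the limit > 4000 nM. Compound 1 therefore stands at the edge of what the assay reports, as the limit of > 4000 nM in this assay, at which 2 of the 2 values shown sit, shows. Compound 3 `CCOc1ccc(NC2=CC(=O)c3c(nc4n3[C@H]3OC[C@@H](O)[C@H]3OC4)C2=O)cc1` differs from compound 1 by ethoxy in place of hydrogen on an aromatic carbon. Within the data shown here, no step between measured compounds that differ in one place exists, so the change has no measured precedent. The expected step is a step that the limit leaves unreadable from compound 1 to compound 3, meaning none beyond the scatter in this assay. Compound 3 is estimated at 6000 nM, between 2000 nM and 20000 nM, most likely again reported only as a limit.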

Compound 3, half-maximal inhibitory concentration: > 4000 nM
Compound 3 was reported as a limit; the forecaster's own chance of this, stated with the estimate: 80%; the middle value lies beyond the limit too.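

No step can be read from compound 1 to compound 3 in this assay, since both give only a limit, not a number. The compounds shown leave open how strongly any of them inhibits, and whether ethoxy in place of hydrogen changes that at all.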